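The source may report more compounds than this note shows. Statements on the series, on what has been measured and on what is new or still open speak of the compounds shown alone.

Compound 1 `O=C(Nc1ccc(Cl)c(-c2nnc3c(Cl)cccn23)c1)c1ccc(C(F)(F)F)cc1Cl` gives > 100000 nM in a functional assay on AN3-CA cells (Homo sapiens) for antiproliferative activity, read by MTT assay, with a stated time of 72 h; a higher number here means a weaker inhibitor, a lower number a stronger inhibitor.
Compound 2 `O=C(Nc1ccc(Cl)c(-c2nnc3c(Cl)cccn23)c1)c1ccccn1` gives > 100000 nM in this assay.
Compound 3 `O=C(Nc1ccc(Cl)c(-c2nnc3c(Cl)cccn23)c1)c1cccc(Cl)c1` gives 68400 nM in this assay.

All three share one core and differ only in the group attached to the carbonyl carbon of the amide. The values of compound 1 and compound 2 are limits of the assay rather than numbers, as the limit of > 100000 nM in this assay, at which 2 of the 3 values shown sit, states, so compound 1 stands at the weak end of what the assay can report. Among the measured compounds shown here, compound 3 is the only one with a number, and the step of an at least 1.4-fold lower number from compound 2 to compound 3 (0.16 log units; that floor lies within the scatter) has a floor that lies within the scatter, so it does not show a real difference.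

Compound 4 `O=C(Nc1ccc(Cl)c(-c2nnc3c(Cl)cccn23)c1)c1ccc(Cl)cc1Cl` has not yet been measured. It differs from compound 1 by chloro in place of trifluoromethyl on an aromatic carbon. For the measured compounds named here, no measured step covers this change; the one measured step concerns a different exchange on the carbonyl carbon, and the neighbours of compound 1 sit at the limit or close to it. The expectation for compound 4 is therefore a step of an at least 1.1-fold lower number from compound 1 to compound 4 (0.04 log units; that floor lies within the scatter) of no size beyond the scatter, and compound 4 is estimated at 90000 nM in this assay, within 35000 nM to 300000 nM, with a real chance that only a limit is reported.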

Compound 4, half-maximal inhibitory concentration: 84800 nM
Estimate against measurement, compound 4: 1.1-fold (0.03 log units) above, and the stated range covers the measured number.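

The exchange of trifluoromethyl for chloro gives an at least 1.1-fold lower number from compound 1 to compound 4 (0.07 log units; that floor lies within the scatter), and the exchange of pyridin-2-yl for 2,4-dichlorophenyl gives an at least 1.1-fold lower number from compound 2 to compound 4 (0.07 log units; that floor lies within the scatter); compound 1 and compound 2 carry only limits, so neither step can be read as a real change. Among the compounds shown here, the one comparison between two actual numbers is a 1.2-fold higher number from compound 3 to compound 4 (0.09 log units; within the scatter), so 3-chlorophenyl and 2,4-dichlorophenyl on the carbonyl carbon cannot be told apart in this assay. Chloro and trifluoromethyl at this position are therefore not separated by these data, and the set as a whole stays at the weak end of the measurable range: the limit of > 100000 nM in this assay, at which 2 of the 4 values shown sit.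

Still open, from the compounds shown here alone, is whether a group of a different kind on this aromatic carbon, such as an amine or a carboxylic acid, would move the number by more than the scatter. Also open, going by these compounds, is whether a change to the shared core, rather than to the aromatic ring on the carbonyl carbon, would bring these compounds away from that weak end.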